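This account rests on a few compounds, and the source may have more. Where it says the series, first, only, none or still open, it means among the compounds named here.

Two compounds in this study share one core and differ only in the aryl group carried on an amine nitrogen in a ring. Compound 1 `O=C(CN1CCN(c2ccccc2F)CC1)Nc1nc2ccccc2[nH]1` gives 47.7% in a functional assay, read by spectrophotometry, with a stated time of 30 min, tested at 100 ug/mL; on this read-out lower numbers stand for a weaker effect and higher numbers for a stronger effect at the one concentration tested. Compound 2 `O=C(CN1CCN(c2ncccn2)CC1)Nc1nc2ccccc2[nH]1` gives 46.5% in this assay and thus stands lowest of the two numbers shown, with compound 1 nearest; the step of a number 1.2 percentage points lower from compound 1 to compound 2 (within the scatter) lies within the scatter, so the two values cannot be told apart. Compound 3 `COc1ccccc1N1CCN(CC(=O)Nc2nc3ccccc3[nH]2)CC1` has not yet been measured. It differs from compound 2 by 2-methoxyphenyl in place of pyrimidin-2-yl on an amine nitrogen in a ring. Within the data shown here, the only measured step that bears on this change is the one from compound 1 to compound 2, which exchanged the group at the same place and stayed within the scatter. On that basis compound 3 is expected to show no step beyond the scatter, a number 0.5 percentage points lower from compound 2 to compound 3 (within the scatter). Compound 3 is therefore estimated at 46% in this assay, with an expected range from 36% to 56%.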

Compound 3, a percentage reported as activity, at one concentration (the size of the read-out at that concentration, not a potency): 43.2%
Compound 3: middle estimate off by 2.8 percentage points, on the high side; low and high end bracket the measured number.
By their numbers in this assay, from the lowest: compounds 3, 2 and 1 (each within the scatter of the next).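

In this assay, 2-methoxyphenyl in place of pyrimidin-2-yl on an amine nitrogen in a ring gives a number 3.3 percentage points lower from compound 2 to compound 3 (within the scatter) and methoxy in place of fluoro on an aromatic carbon gives a number 4.5 percentage points lower from compound 1 to compound 3 (within the scatter) on the same nitrogen-bound aryl group. The earlier pair showed a single exchange at this place, whereas these steps add a larger group with a ring of carbon only and show that the three aryl groups cannot be told apart on this read-out. Nothing available explains why the three values lie so close.

The compounds shown leave open whether a non-aromatic group on this nitrogen, such as an acetyl group or a longer alkyl chain, would give a step beyond the scatter. They also leave open whether a phenyl ring bearing a carboxylic acid or an amine would do so.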